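This account rests on a few compounds, and the source may have more. Where it says the series, first, only, none or still open, it means among the compounds named here.

In an assay on membranes from brain for binding affinity to neutral cholesterol ester hydrolase 1 (Mus musculus), read by fluorescence, with stated times of 1 h and 30 min (on this read-out higher numbers stand for weaker inhibition and lower numbers for stronger inhibition), compound 1 `O=C(N1CCCN(Cc2ccc(OCc3ccccc3)cc2)CC1)n1cccn1` gives > 100000 nM, which is a limit of the assay and not a number.
Compound 2 `N#Cc1cnn(C(=O)N2CCCN(Cc3ccc(OCc4ccccc4)cc3)CC2)c1` gives > 100000 nM, again a limit.
Compound 3 `CN(CCN(C)C(c1ccc(OCc2ccccc2)cc1)c1ccc(OCc2ccccc2)cc1)C(=O)n1cccn1` gives > 1000000 nM, also a limit.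

Compound 2 differs from compound 1 by cyano in place of hydrogen on an aromatic carbon. Both values sit at the limit of > 100000 nM in this assay, at which 2 of the 3 values shown sit, so the step that the two limits leave unreadable from compound 1 to compound 2 cannot be sized. Compound 4 `CN(CCN(C)C(c1ccc(OCc2ccccc2)cc1)c1ccc(OCc2ccccc2)cc1)C(=O)n1cc(C#N)cn1` differs from compound 3 by cyano in place of hydrogen on an aromatic carbon, the same change at the same place. How the core of compound 3 differs from the core of compound 1 is not broken down here. Compound 4 is expected to stay at the limit, with an expected step of a number no higher from compound 3 to compound 4 (the limit leaves the size open), because compound 3 sits at the limit of > 1000000 nM in this assay, at which 1 of the 3 values shown sits. The estimate for compound 4 is 1000000 nM, most likely reported only as a limit once more.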

Compound 4, half-maximal inhibitory concentration: > 1000000 nM
Compound 4: a limit, no number; the forecaster's own chance of this, stated with the estimate: 85%; the middle value lies on the limit itself.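

Compound 3 and compound 4 both sit at a limit of the assay and not at a number, so no step can be read between them: the limit of > 1000000 nM in this assay, at which 2 of the 4 values shown sit.

The compounds shown leave open how strongly any of them inhibits, and whether cyano in place of hydrogen changes that at all.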